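The source may report more compounds than this note shows. Statements on the series, on what has been measured and on what is new or still open speak of the compounds shown alone.

Measured compounds:

Compound 1 `Cc1ccc(NC(=O)CN2CCN(c3nnc(Cc4ccccc4)c4ccccc34)CC2)c(C)c1` — "not active" (no number reported) in a functional assay on A549 cells (Homo sapiens) for cytotoxicity, read by MTT assay, with a stated time of 72 h; a lower number here means a stronger inhibitor, a higher number a weaker inhibitor
Compound 2 `Cc1ccccc1NC(=O)CN1CCN(c2nnc(Cc3ccncc3)c3ccccc23)CC1` — 43100 nM
Compound 3 `Cc1ccc(NC(=O)CN2CCN(c3nnc(Cc4ccncc4)c4ccccc34)CC2)c(C)c1` — 45000 nM

Among the compounds with values here, compound 1 is reported in this assay only as "not active" (no number reported), with no number attached, so it cannot be placed among the measured values; compound 2 and compound 3 both give weak values, and the one measured step, a 1.0-fold higher number from compound 2 to compound 3 (0.02 log units; within the scatter), shows that adding a methyl to the aromatic ring on the amide nitrogen did not move the read-out beyond the scatter.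

Compound 4 `O=C(CN1CCN(c2nnc(Cc3ccccc3)c3ccccc23)CC1)Nc1cccc(F)c1` is the untested compound. It differs from compound 1 by 3-fluorophenyl in place of 2,4-dimethylphenyl on an amide-type nitrogen. Within the data shown here, the only measured step that touches the same region of the molecule is the one from compound 2 to compound 3, and it was flat; there is no measured step that exchanges a methyl-bearing ring for a fluorine-bearing one, and no step that links the benzyl series of compound 1 to the pyridinylmethyl series of compound 2 and compound 3. Among the measured compounds shown here, with compound 1 giving no number, no directional step can be computed for this change. The expectation therefore rests on the weak values of compound 2 and compound 3 and on the absence of a reported number for compound 1.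

Compound 4 is estimated to give about 60000 nM, with a likely range of 20000 nM to 200000 nM, and a real chance that it, too, is reported without a number.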

Compound 4, half-maximal inhibitory concentration: 130000 nM
For compound 4 the middle estimate is 2.2-fold (0.34 log units) below the measured one; the range from low to high includes it.
By their numbers in this assay, from the lowest: compounds 2 and 3 (each within the scatter of the next); then compound 4.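

No new step can be read: in this assay compound 4 gives 130000 nM, while compound 1, which differs from it in one place, is reported only as "not active" (no number reported). No supporting evidence bears on this result. The compounds shown leave open how exchanging 2,4-dimethylphenyl for 3-fluorophenyl changes the read-out when both partners carry a number.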